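The source may report more compounds than this note shows. Statements on the series, on what has been measured and on what is new or still open speak of the compounds shown alone.

Measured in a functional assay (aorta) with Rattus norvegicus as the target; a lower number here means that less compound is needed, a higher number that more compound is needed for the effect:

Compound 1 `CN(C)/C(=N\C#N)C1=CC(C)(C)Oc2ccc([N+](=O)[O-])cc21`: > 31600 nM, a limit of the assay and not a number.
Compound 2 `CN(C)/C(=N\C#N)C1=CC(C)(C)Oc2ccc(S(C)(=O)=O)cc21`: > 31600 nM, a limit of the assay and not a number.

Compound 1 offers no number as a starting point, only its limit in this assay. Among the measured compounds shown here, the whole series so far shows the same picture, with the limit of > 31600 nM in this assay, at which 2 of the 2 values shown sit.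

Compound 3 `CN(C)/C(=N\S(N)(=O)=O)C1=CC(C)(C)Oc2ccc([N+](=O)[O-])cc21` keeps the nitro group of compound 1 and carries sulfamoyl in place of cyano on a double-bonded nitrogen.

For the measured compounds named here, the only measured step is a step that the two limits leave unreadable from compound 1 to compound 2. Going by the values given here, it puts methylsulfonyl in place of nitro on an aromatic carbon, leaves the cyano untouched and has no readable size, so no measured step bears directly on the new change. No step beyond the scatter can therefore be expected in either direction in this assay, and the most likely outcome is another limit. The expected step is an at least 1.0-fold lower number from compound 1 to compound 3 (0.02 log units; that floor lies within the scatter). The estimate for compound 3 is 30000 nM, with an expected range from 6000 nM to 100000 nM.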

Compound 3, half-maximal effective concentration: > 31600 nM
Compound 3 was reported as a limit; the forecaster's own chance of this, stated with the estimate: 70%; middle value at least 1.0-fold (0.02 log units) from the limit.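

In this assay, compound 3 gives > 31600 nM, which is a limit and not a number. Compound 1 also offers only a limit, so no step can be read between compound 1 and compound 3. The series remains uniform: the limit of > 31600 nM in this assay, at which 3 of the 3 values shown sit.

The compounds shown leave open what effect, if any, sulfamoyl in place of cyano has on the concentration needed in this assay.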